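The source may hold more compounds than are shown below. What is called first, only, known or untested is meant among the compounds shown, and "the series" means these compounds.

In a functional assay on HL-60 cells (Homo sapiens) for inhibition, with a stated time of 72 h (a higher number here means a weaker inhibitor, a lower number a stronger inhibitor), compound 2 `OC[C@H]1O[C@@H](n2cnc3c(Cn4ccc5ccccc54)ncnc32)[C@H](O)[C@@H]1O` gives 5700 nM and lies within the scatter of compound 1 `CN(Cc1ncnc2c1ncn2[C@@H]1O[C@H](CO)[C@@H](O)[C@H]1O)c1ccccc1` which gives 4000 nM in the same read-out. Going to compound 3 `OC[C@H]1O[C@@H](n2cnc3c(CSCc4ccccc4)ncnc32)[C@H](O)[C@@H]1O` the change is benzylsulfanyl in place of 1H-indol-1-yl on a saturated chain carbon bound to an aromatic carbon and it puts benzylsulfanyl in place of 1H-indol-1-yl on a saturated chain carbon bound to an aromatic carbon. Going by the values given here, the one measured step at this place, a 1.4-fold higher number from compound 1 to compound 2 (0.15 log units; within the scatter), stays within the scatter and gives no direction, so no step beyond the scatter is expected in this assay here. The estimated step is a 1.3-fold lower number from compound 2 to compound 3 (0.10 log units; within the scatter) on this single precedent. For compound 3 the estimate is 4500 nM with an expected range of 1500 nM to 14000 nM in this read-out.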

Compound 3, half-maximal inhibitory concentration: 10700 nM
Estimate against measurement, compound 3: 2.4-fold (0.38 log units) below, and the stated range covers the measured number.
By their numbers in this assay, from the lowest: compounds 1, 2 and 3 (each within the scatter of the next, the first and the last beyond it).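

In this assay, going by these compounds alone, there is a 1.9-fold higher number from compound 2 to compound 3 (0.27 log units; within the scatter) for benzylsulfanyl in place of 1H-indol-1-yl, while there is a 2.7-fold higher number from compound 1 to compound 3 (0.43 log units; beyond the scatter) for benzylsulfanyl in place of methyl(phenyl)amino, the first modest step beyond the scatter at this place. On a saturated chain carbon bound to an aromatic carbon, benzylsulfanyl thus separates only from methyl(phenyl)amino, and 1H-indol-1-yl stays within the scatter of both. No available measurement offers a reason for these steps.

From the compounds shown here alone, it remains open whether a morpholine or a carboxylic acid at this place would shift the number beyond the scatter relative to all three compounds, and in which direction.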